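Working notes on a series: compound 4 from compound 2

The source may report more compounds than this note shows. Statements on the series, on what has been measured and on what is new or still open speak of the compounds shown alone.

Values measured in an ADME assay on the whole organism for inhibition, with Echinochloa crus-galli var. formosensis as the target, with a stated time of 4 days; a higher number here means a weaker inhibitor, a lower number a stronger inhibitor:

compound 1, `CCN(CC)c1nc(Cl)nc(NC(C)c2ccccc2)n1`, gives 1510 nM
compound 2, `CC[C@H](C)Nc1nc(Cl)nc(N[C@@H](C)c2ccccc2)n1`, gives 14100 nM
compound 3, `CC[C@@H](C)Nc1nc(Cl)nc(N[C@H](C)c2ccccc2)n1`, gives 4570 nM

Compound 2 stands at the highest number of the three, so it is the weakest inhibitor measured here; its nearest neighbour is compound 3, and compound 1 is furthest from it. Among the measured compounds shown here, the one step between neighbours that differ in a single place is a 3.1-fold lower number from compound 2 to compound 3 (0.49 log units; beyond the scatter), and it is tied to the fact that compounds 2 and 3 differ only in the configuration as drawn; the two compounds are mirror images, so the change in number goes with configuration alone.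

Compound 4, `CCNc1nc(Cl)nc(N[C@@H](C)c2ccccc2)n1`, is not yet measured. It keeps the configuration of compound 2 at the carbon bearing the phenyl ring and changes (hydrogen in place of ethyl on a saturated chain carbon bound to a nitrogen on an aromatic ring and a saturated chain carbon). For the measured compounds named here, nothing measured in this set bears on sec-butyl to ethyl directly: the only step recorded concerns inversion of both stereocentres, and compound 1 carries a different amine altogether, so its value gives only a loose anchor. Compound 4 drops the stereocentre that was inverted on going from compound 2 to compound 3, which removes one of the two elements behind that step.

The expectation for compound 4 in this assay is therefore a step of a 2.0-fold lower number from compound 2 to compound 4 (0.30 log units; within the scatter), toward a lower number but of uncertain size. The estimate for compound 4 is 7000 nM, with a range from 2500 nM to 20000 nM.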

Compound 4, half-maximal inhibitory concentration: 30900 nM
For compound 4 the middle estimate is 4.4-fold (0.64 log units) below the measured one; measured number above the stated range.
By their numbers in this assay, from the lowest: compound 1; then compound 3; then compound 2; then compound 4.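

In this assay, hydrogen in place of ethyl on a saturated chain carbon bound to a nitrogen on an aromatic ring and a saturated chain carbon, read as sec-butyl to ethyl, gives a 2.2-fold higher number from compound 2 to compound 4 (0.34 log units; beyond the scatter) and so a modestly weaker inhibitor. This shows that the position responds to the chain itself with the remaining stereocentre kept as drawn, whereas the earlier step of a 3.1-fold lower number from compound 2 to compound 3 (0.49 log units; beyond the scatter) showed a response to configuration alone, with both stereocentres inverted. The change to ethyl also removes the stereocentre on the sec-butyl group, so this single step does not separate the shorter chain from the loss of that stereocentre, and nothing measured here gives a cause for the step.

Open, going by these compounds, is whether the trend runs on through other amine substituents, such as isopropyl, cyclopropyl or a longer chain like n-butyl, since sec-butyl and ethyl give only two points at this position. Also open, on these data alone, is how much of the step of a 3.1-fold lower number from compound 2 to compound 3 (0.49 log units; beyond the scatter) belongs to each of the two stereocentres, which a single-centre inversion of compound 4 at its remaining stereocentre would begin to address.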